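The source may hold more compounds than are shown below. What is called first, only, known or untested is meant among the compounds shown, and "the series" means these compounds.

Of the three numbers in hand from a functional assay on SK-MEL-2 cells (Homo sapiens) for cytotoxicity, read by sulforhodamine B assay, with a stated time of 48 h, tested at 100 uM (a higher number here means a weaker effect of the compound at the concentration tested, a lower number a stronger effect), compound 2 `COc1ccc(C(=O)/C=C/c2cc(-c3cc(OC)c(OC)c(OC)c3)n[nH]2)cc1OC` stands lowest, giving -96%. Compound 1 `COc1cc(-c2cc(/C=C/C(=O)c3ccc(Cl)c(Cl)c3)[nH]n2)cc(OC)c1OC` gives -60% and compound 3 `COc1cc(-c2cc(/C=C/C(=O)c3ccc(F)c(F)c3)[nH]n2)cc(OC)c1OC` gives -64%; between these two the step is a number 4 percentage points lower from compound 1 to compound 3 (within the scatter), so they sit together, whereas a number 36 percentage points lower from compound 1 to compound 2 (beyond the scatter) and a number 32 percentage points higher from compound 2 to compound 3 (beyond the scatter) set compound 2 apart from both.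

Compound 4 `COc1cc(C(=O)/C=C/c2cc(-c3cc(OC)c(OC)c(OC)c3)n[nH]2)cc(OC)c1OC` differs from compound 2 by methoxy in place of hydrogen on an aromatic carbon. For the measured compounds named here, no step in hand adds or removes a single methoxy group on the phenyl at the carbonyl carbon; the two large steps, a number 36 percentage points lower from compound 1 to compound 2 (beyond the scatter) and a number 32 percentage points higher from compound 2 to compound 3 (beyond the scatter), exchange 3,4-dimethoxyphenyl for a dihalophenyl as a whole, and both read in the direction that the 3,4-dimethoxyphenyl on the carbonyl carbon gives the lowest number. They bear on compound 4 only in that the change from compound 2 keeps that motif and extends it. Going by the values given here, with no direct precedent, a step of a number 3 percentage points higher from compound 2 to compound 4 (within the scatter) is expected, which is none beyond the scatter; compound 2 already lies near the bottom of the scale in this assay, leaving little room for a lower number. Compound 4 is therefore estimated at -93% in this assay, within a range of -100% to -78%.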

Compound 4, a percentage reported as activity, at one concentration (the size of the read-out at that concentration, not a potency): -96%
Compound 4: the middle estimate sits 3 percentage points above what was measured, within the range that was stated.
By their numbers in this assay, from the lowest: compounds 2 and 4 (each within the scatter of the next); then compounds 3 and 1 (each within the scatter of the next).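

In this assay, for the compounds shown here, methoxy in place of hydrogen on an aromatic carbon of the phenyl at the carbonyl carbon, ortho to a methoxy group, gives no change at the digits printed from compound 2 to compound 4 (within the scatter), the first step that changes a single substituent on that ring rather than exchanging the whole aryl group. The low number seen with the 3,4-dimethoxyphenyl on the carbonyl carbon therefore survives this addition, and the position accepts a methoxy group without a change beyond the scatter. The read-out comes from one concentration and is not a potency, so this shows tolerance of the change in this assay, not equal potency, and no supporting measurement accounts for the flat step.

Open, from the compounds shown here alone, is whether a hydroxyl group, an amine or a carboxylic acid in the same place would leave the read-out as methoxy does, or whether a longer chain such as butoxy would shift it. Also open, going by these compounds, is whether compound 2 and compound 4 would still read alike at a lower concentration, away from the bottom of the scale.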